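A few compounds are considered here, and "the series" means these few. Any claim that something is new, unique, unknown or untested is made for them only; others in the source may bear on it.

Two measured compounds share a core that differs only in the group attached through a nitrogen to one ring carbon. Compound 1, `COc1ccc(CNc2nc3cc(N)cc(N)c3nc2-c2ccccc2)cc1OC`, carries a 3,4-dimethoxyphenyl group on a saturated chain carbon bound to that nitrogen. In a functional assay on COLO 205 cells (Homo sapiens) for inhibition, read by sulforhodamine B assay, with a stated time of 48 h (a higher number here means that more compound is tolerated, a lower number that less compound is tolerated), compound 1 gives < 100000 nM, which is a limit of the assay rather than a number. Compound 2, `Nc1cc(N)c2nc(-c3ccccc3)c(NCc3ccc(F)cc3)nc2c1`, carries a 4-fluorophenyl group in the same position. In this assay compound 2 gives < 100000 nM, again a limit and not a number. The step that the two limits leave unreadable from compound 1 to compound 2 therefore cannot be read as a size, and what the two values show is only that both sit at the limit of < 100000 nM in this assay, at which 2 of the 2 values shown sit.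

Compound 3, `Nc1cc(N)c2nc(-c3ccccc3)c(Sc3ccc(F)cc3)nc2c1`, is not yet measured. The change from compound 2 is (4-fluorophenyl)sulfanyl in place of (4-fluorobenzyl)amino on an aromatic carbon. Going by the values given here, no measured step bears on this exchange, so compound 2 offers only a limit as the starting point. The step that the limit leaves unreadable from compound 2 to compound 3 is an estimate that rests on nothing more than that limit. Compound 3 is expected to give 20000 nM, within a range from 2000 nM to 100000 nM, in this assay.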

Compound 3, concentration lethal to 50% of the cells: < 100000 nM
Compound 3 ended at the assay's limit; the forecaster's own chance of this, stated with the estimate: 50%; the middle value lies beyond the limit too.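

Going by these compounds alone, compound 3 also gives a limit of the assay rather than a number, so no step from compound 2 to compound 3 can be read as a size: (the limit of < 100000 nM in this assay, at which 3 of the 3 values shown sit).

The compounds shown leave open how far each one lies from that limit in this assay and whether either exchange on the shared core changes the true value at all.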